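A few compounds are considered here, and "the series" means these few. Any claim that something is new, unique, unknown or untested is made for them only; others in the source may bear on it.

The measured compounds:
compound 1 `CCCCNc1cc(C)nc2c(-c3ccc(Cl)cc3Cl)nn(C)c12`; in an assay on HEK293 cells for displacement of a labelled ligand from corticotropin-releasing factor receptor 1 (Homo sapiens) (on this read-out higher numbers stand for weaker inhibition and lower numbers for stronger inhibition), compound 1 gives 170 nM.
compound 2 `CCN(CC1CC1)c1cc(C)nc2c(-c3ccc(Cl)cc3Cl)nn(C)c12`; in this assay compound 2 gives 4.4 nM.

Compound 2 holds the lowest of the two numbers; its nearest neighbour is compound 1, and the step of a 39-fold lower number from compound 1 to compound 2 (1.59 log units; beyond the scatter) separates the two. Compound 3 `Cc1cc(N(CC(C)C)CC2CC2)c2c(n1)c(-c1ccc(Cl)cc1Cl)nn2C` differs from compound 2 by isopropyl in place of methyl on a saturated chain carbon bound to a nitrogen on an aromatic ring. Going by the values given here, the only measured step, a 39-fold lower number from compound 1 to compound 2 (1.59 log units; beyond the scatter), replaced butylamino with (cyclopropylmethyl)(ethyl)amino and moved the number a great deal, but it bears only loosely on the present change, which keeps the cyclopropylmethyl and takes ethyl to isobutyl. Among the compounds with values here, no measured pair shows that change, so the expectation rests on compound 2 alone. The expected step is a 1.4-fold higher number from compound 2 to compound 3 (0.13 log units; within the scatter), staying within the scatter or showing a small loss. The estimate for compound 3 in this assay is 6 nM, ranging from 2 nM to 20 nM.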

Compound 3, inhibition constant: 3.7 nM
Estimate against measurement, compound 3: 1.6-fold (0.21 log units) above, and the stated range covers the measured number.
By their numbers in this assay, from the lowest: compounds 3 and 2 (each within the scatter of the next); then compound 1.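

Isopropyl in place of methyl on a saturated chain carbon bound to a nitrogen on an aromatic ring gives a 1.2-fold lower number from compound 2 to compound 3 (0.08 log units; within the scatter) in this assay and so leaves the reading unresolved: at this place, ethyl and isobutyl cannot be told apart, although the entering group has more heavy atoms. The large gain over butylamino also survives this change, as a 46-fold lower number from compound 1 to compound 3 (1.66 log units; beyond the scatter) shows alongside the earlier step, so it is not confined to (cyclopropylmethyl)(ethyl)amino. Nothing available explains either step.

The compounds shown do not separate the part played by cyclopropylmethyl from that of the second group on the nitrogen, as both enter together in each step from butylamino. Going by these compounds, it also remains open how far this tolerance extends, for instance to a longer chain such as hexyl or to a chain ending in a carboxylic acid.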